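One Added Hydroxy on Compound 2

The source may report more compounds than this note shows. Statements on the series, on what has been measured and on what is new or still open speak of the compounds shown alone.

In a functional assay, with a stated time of 30 min (on this read-out lower numbers stand for stronger inhibition and higher numbers for weaker inhibition), compound 1 `O=C(/C=C/c1ccc(O)c(O)c1)CC(=O)/C=C/c1cccc(O)c1O` gives 19000 nM, compound 2 `O=C(/C=C/c1cccc(O)c1)CC(=O)/C=C/c1cccc(O)c1O` gives 29000 nM and compound 3 `O=C(/C=C/c1ccc(O)c(O)c1)CC(=O)/C=C/c1cc(O)ccc1O` gives 60000 nM. Compound 2 cannot be told apart from compound 1, and its number is lower than that of compound 3.

Compound 4 `O=C(/C=C/c1cc(O)ccc1O)CC(=O)/C=C/c1cccc(O)c1O` has not yet been measured. It differs from compound 2 by hydroxy in place of hydrogen on an aromatic carbon, which turns 3-hydroxyphenyl into 2,5-dihydroxyphenyl (hydroxy in place of hydrogen on an aromatic carbon). Within the data shown here, two measured steps bear on this, though neither is the same change. The step of a 1.5-fold higher number from compound 1 to compound 2 (0.18 log units; within the scatter) exchanges hydroxy and hydrogen on an aromatic carbon and stays within the scatter. The modest step of a 3.2-fold higher number from compound 1 to compound 3 (0.50 log units; beyond the scatter) brings in the 2,5-dihydroxyphenyl group that compound 4 also carries. Together they suggest little movement, with a slight lean towards weaker inhibition. In this assay the estimated step is a 1.2-fold higher number from compound 2 to compound 4 (0.08 log units; within the scatter), which is expected to stay within the scatter. For compound 4 the estimated value is 35000 nM, with an expected range from 14000 nM to 85000 nM.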

Compound 4, half-maximal inhibitory concentration: 27000 nM
Compound 4: middle estimate off by 1.3-fold (0.11 log units), on the high side, and the stated range covers the measured number.
By their numbers in this assay, from the lowest: compounds 1, 4 and 2 (each within the scatter of the next); then compound 3.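

On the 3-hydroxyphenyl group, a hydroxy on the aromatic carbon ortho to a large group and para to a hydroxy group gives no readable change in this assay, with a 1.1-fold lower number from compound 2 to compound 4 (0.03 log units; within the scatter). The 2,5-dihydroxyphenyl group therefore does not always go with weaker inhibition: a 2.2-fold lower number from compound 3 to compound 4 (0.35 log units; beyond the scatter), whereas a 1.4-fold higher number from compound 1 to compound 4 (0.15 log units; within the scatter), so among these compounds the loss appears only where that group stands in place of 2,3-dihydroxyphenyl. Nothing given here explains these numbers.

Going by these compounds, it remains open whether a methoxy group, a fluorine atom or an amine on this same aromatic carbon would give a similar number. On these data alone, it is also open whether a plain phenyl group in place of 3-hydroxyphenyl would keep the inhibition.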